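The source may hold more compounds than are shown below. What is called first, only, known or untested is meant among the compounds shown, and "the series" means these compounds.

Among the measured compounds shown here, compound 3 `COc1ccc2c(=O)c(/C=C/C(=O)Nc3ccc(F)cc3)coc2c1` gives 26800 nM in a functional assay on A549 cells (Homo sapiens) for inhibition, read by MTT assay, with a stated time of 48 h (on this read-out higher numbers stand for weaker inhibition and lower numbers for stronger inhibition), and is the only one of the three values seen that is a number rather than a limit. Compound 1 `COc1ccc2c(=O)c(/C=C/C(=O)NCc3ccccc3F)coc2c1` sits at the limit > 100000 nM in this assay. Compound 2 `COc1ccc2c(=O)c(/C=C/C(=O)Nc3ccc(Cl)cc3)coc2c1` likewise sits at the limit > 100000 nM. Compound 4 `COc1ccc2c(=O)c(/C=C/C(=O)Nc3ccc(C)cc3)coc2c1` differs from compound 3 by methyl in place of fluoro on an aromatic carbon. The step that bears most directly is an at least 3.7-fold lower number from compound 2 to compound 3 (0.57 log units; beyond the scatter), on the same aromatic carbon; the steps a step that the two limits leave unreadable from compound 1 to compound 2 and an at least 3.7-fold lower number from compound 1 to compound 3 (0.57 log units; beyond the scatter) add little beyond bounds because the limit of > 100000 nM in this assay, at which 2 of the 3 values shown sit, caps their size. A swap of one small group for another at that carbon has been read once as at least modest, so compound 4 is expected near 40000 nM, between 12000 nM and 120000 nM. The expected step of a 1.5-fold higher number from compound 3 to compound 4 (0.17 log units; within the scatter) may fall within or beyond the scatter.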

Compound 4, half-maximal inhibitory concentration: 17500 nM
Estimate against measurement, compound 4: 2.3-fold (0.36 log units) above; the measured number falls inside the stated range.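

At the carbon para to a large group, the swap of fluoro for methyl does not separate the two compounds: a 1.5-fold lower number from compound 3 to compound 4 (0.19 log units; within the scatter). Chloro at that carbon now stands apart from both fluoro and methyl, with an at least 5.7-fold lower number from compound 2 to compound 4 (0.75 log units; beyond the scatter), and the change from 2-fluorobenzyl to 4-methylphenyl on the amide-type nitrogen gives an at least 5.7-fold lower number from compound 1 to compound 4 (0.75 log units; beyond the scatter). Both of these steps are bounds only: the limit of > 100000 nM in this assay, at which 2 of the 4 values shown sit.

Going by these compounds, what an amine, a carboxylic acid or a methoxy group would do at this carbon remains open. Also open, on these data alone, is how a 4-methylbenzyl group on the amide-type nitrogen would read.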